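The compounds below may be only part of what the source reports. "The series", "measured", "known", "first", "only" and "open" are said of these compounds alone.

Measured compounds:
Compound 1, `O=S(=O)(/C=C/c1ccccn1)c1cccc(F)c1`: 1680 nM
Compound 2, `O=S(=O)(/C=C/c1ccc(Cl)cn1)c1ccc(F)cc1`: 4370 nM
Compound 3, `O=S(=O)(/C=C/c1ncccc1Cl)c1ccc(Cl)cc1`: 65 nM

These three compounds were tested in an assay on U2OS cells for activation of nuclear factor erythroid 2-related factor 2 (Homo sapiens), read by beta-arrestin recruitment, with a stated time of 6 h; a higher number here means that more compound is needed for the effect, a lower number that less compound is needed. Compound 2 stands at the top of the three numbers, meaning that of the three it needs the most compound for the effect. The nearest to it is compound 1, whose number is lower by a gap beyond the usual scatter; the furthest is compound 3, whose number is lower by a much wider gap.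

The next compound, compound 4, `O=S(=O)(/C=C/c1ccc(Cl)cn1)c1ccc(Cl)cc1`, has not yet been measured in this assay. It is built from compound 2 by one change: chloro in place of fluoro on an aromatic carbon. The place is on an aromatic carbon of a six-membered aromatic ring of carbon only, para to a large group.

For the measured compounds named here, no pair among the measured compounds differs in this single place, so the size of this step cannot be read off directly. Going by the values given here, compound 3, the only compound carrying chloro on that ring, gives 65 nM, but it also differs from compound 4 elsewhere, so it only hints at direction. A modest move toward a lower number is expected, a 2.4-fold lower number from compound 2 to compound 4 (0.39 log units; beyond the scatter). Compound 4 is estimated at 1800 nM, within a range from 400 nM to 7000 nM.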

Compound 4, half-maximal effective concentration: 3160 nM
Beside the measured number, compound 4's estimate is 1.8-fold (0.24 log units) below it; low and high end bracket the measured number.
By their numbers in this assay, from the lowest: compound 3; then compounds 1, 4 and 2 (each within the scatter of the next, the first and the last beyond it).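

In this assay, chloro in place of fluoro, on an aromatic carbon para to a large group, gives a 1.4-fold lower number from compound 2 to compound 4 (0.14 log units; within the scatter), a step within the usual scatter, so at this place the two halogens cannot be told apart on this core. For the compounds shown here, this is the first direct reading of the place, since no earlier pair differed here alone, and it shows that on this core the chloro shared with compound 3 does not by itself bring a step beyond the scatter. No measurement is at hand that would explain why the two groups read alike here.

Only these two halogens are seen at this place, so a methyl, a methoxy, a trifluoromethyl or a nitrile on the same carbon could still move the number by more, or by no more, than this swap does. Also open, on these data alone, is whether the same exchange of fluoro for chloro stays this small when the rest of the molecule is that of compound 3 rather than that of compound 2.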